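Swapping 4-fluorophenyl for 2-hydroxyphenyl in the series

The compounds below may be only part of what the source reports. "The series", "measured", "known", "first", "only" and "open" are said of these compounds alone.

In a functional assay on HepG2 cells (Homo sapiens) for antiproliferative activity, read by MTT assay, with a stated time of 48 h (a higher number here means a weaker inhibitor, a lower number a stronger inhibitor), compound 1 (`CC(=O)N1N=C(c2ccc3ccccc3c2)OC1c1ccc(Cl)cc1`) gives 1.88 ug/mL and compound 2 (`CC(=O)N1N=C(c2ccc3ccccc3c2)OC1c1cccc(F)c1`) gives 1.86 ug/mL while compound 3 (`CC(=O)N1N=C(c2ccc3ccccc3c2)OC1c1ccc(F)cc1`) gives 1.82 ug/mL and so stands level with both within the scatter. Compound 4 (`CC(=O)N1N=C(c2ccc3ccccc3c2)OC1c1ccccc1O`) has 2-hydroxyphenyl in place of 4-fluorophenyl on a saturated ring carbon. The steps bearing on this place are a 1.0-fold lower number from compound 1 to compound 3 (0.01 log units; within the scatter) and a 1.0-fold lower number from compound 2 to compound 3 (0.01 log units; within the scatter) and also a 1.0-fold lower number from compound 1 to compound 2 (0.00 log units; within the scatter) and all of them lie within the scatter. None of them brings in 2-hydroxyphenyl, so they offer only limited guidance. In this assay an estimated 1.0-fold higher number from compound 3 to compound 4 (0.02 log units; within the scatter) is therefore expected, which means no step beyond the scatter and no firm direction. The expected value for compound 4 is 1.9 ug/mL with an estimated range from 1 ug/mL to 4 ug/mL for this compound.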

Compound 4, half-maximal inhibitory concentration: 1.84 ug/mL
Compound 4: middle estimate off by 1.0-fold (0.01 log units), on the high side; the range from low to high includes it.
By their numbers in this assay, from the lowest: compounds 3, 4, 2 and 1 (each within the scatter of the next).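

The saturated ring carbon now carries 2-hydroxyphenyl, which has a hydrogen-bond donor that 4-fluorophenyl lacks, yet in this assay all three new steps stay within the scatter (a 1.0-fold higher number from compound 3 to compound 4 (0.00 log units; within the scatter); a 1.0-fold lower number from compound 2 to compound 4 (0.00 log units; within the scatter); a 1.0-fold lower number from compound 1 to compound 4 (0.01 log units; within the scatter)). The level picture therefore extends from the halogen-bearing phenyl groups to a hydroxy-bearing one, and none of the four compounds stands apart. No evidence on why these values coincide is available.

As far as these compounds go, whether an amine or a carboxylic acid on the phenyl ring would keep the numbers level stays open. The same holds for a longer chain in place of that ring.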